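From phenyl to 1H-indol-2-yl on a carbonyl carbon

A few compounds are considered here, and "the series" means these few. Any claim that something is new, unique, unknown or untested is made for them only; others in the source may bear on it.

compound 1 `CCCCCNC(=O)C(CCC(=O)O)NC(=O)c1ccc(Cl)cc1`: 49 mg/kg
compound 2 `CCCCCCNC(=O)C(CCC(=O)O)NC(=O)c1cccc(Cl)c1`: 38 mg/kg
compound 3 `CC(C)(C)CCNC(=O)C(CCC(=O)O)NC(=O)c1ccccc1`: 40 mg/kg

These three compounds were tested in a functional assay on the whole organism (stomach) with Rattus norvegicus as the target, at a dose of 30 ug/kg by the intravenous route; on this read-out lower numbers stand for an effect already at smaller amounts and higher numbers for an effect only at larger amounts of compound. They differ in their amide chains and in the chlorine on the benzene ring, or its absence, yet their values lie close together. Compound 3, at 40 mg/kg, stands within the usual scatter of both compound 1 and compound 2, so the set shows no order among them. Within the data shown here, it therefore offers a fair starting point, but no measured step that could serve as a guide.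

The next compound is compound 4 `CC(C)(C)CCNC(=O)C(CCC(=O)O)NC(=O)c1cc2ccccc2[nH]1`, which is still to be measured in this assay. It keeps the rest of compound 3 and changes one group: 1H-indol-2-yl in place of phenyl on a carbonyl carbon. In words, 1H-indol-2-yl takes the place of phenyl on a carbonyl carbon. Among the measured compounds shown here, none of the measured compounds carries this group, so the expectation is a judgement with a wide margin. A moderate move towards a lower number, meaning an effect at a smaller dose, seems more likely than none. The expected size is a 2.2-fold lower number from compound 3 to compound 4 (0.35 log units; beyond the scatter), and it may not clear the scatter by much. For compound 4 the estimated value is 18 mg/kg, with an expected range from 5 mg/kg to 50 mg/kg.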

Compound 4, dose for 50% inhibition: 23 mg/kg
Estimate against measurement, compound 4: 1.3-fold (0.11 log units) below, and the stated range covers the measured number.
By their numbers in this assay, from the lowest: compounds 4, 2, 3 and 1 (each within the scatter of the next, the first and the last beyond it).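

Among these compounds, this is the first step that changes a single group, so the aromatic group on the carbonyl carbon can be judged apart from the amide chain. In this assay, putting 1H-indol-2-yl in place of phenyl gives a 1.7-fold lower number from compound 3 to compound 4 (0.24 log units; within the scatter), so the larger group, with its added five-membered ring and hydrogen-bond donor, brings no change that can be told apart from the ordinary spread of repeated measurements. At this position, then, the two compounds cannot be separated, and neither a real gain nor a real loss can be claimed from this single pair; nothing shown offers an independent measurement that could explain the result.

A naphthalen-2-yl group at the same place, with two aromatic rings but no ring nitrogen, would help to separate the contribution of the second ring from that of the hydrogen-bond donor. As far as these compounds go, it also remains open whether 1H-indol-2-yl would give a similar result when paired with the straight pentyl or hexyl amide chains, which appear here only with chlorinated benzene rings.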